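The source may report more compounds than this note shows. Statements on the series, on what has been measured and on what is new or still open speak of the compounds shown alone.

Compound 1 `CNC(=O)c1cc(C(=O)NC2CCOCC2)n([C@@H](C)c2ccccc2)n1`: 31 ug/mL
Compound 2 `CNC(=O)c1cc(C(=O)N[C@H]2[C@@H]3COC[C@@H]32)c([C@@H](C)c2ccccc2)o1`: >= 131 ug/mL

Among the measured compounds shown here, in a physicochemical assay for solubility (on this read-out lower numbers stand for lower solubility and higher numbers for higher solubility), compound 1 gives 31 ug/mL, the only plain number among the two values shown. Compound 2 sits at the limit of >= 131 ug/mL in this assay, at which 1 of the 2 values shown sits, which is a limit of the assay and not a number. Compound 3 `CNC(=O)c1cc(C(=O)NC(C)CO)n([C@@H](C)c2ccccc2)n1` has not yet been measured in this assay. Its difference from compound 1 is 1-(hydroxymethyl)ethyl in place of oxan-4-yl on an amide-type nitrogen. For the measured compounds named here, no step between measured compounds is available, so the size of this one is uncertain. For compound 3 a rise in this assay is expected, a 2.9-fold higher number from compound 1 to compound 3 (0.46 log units; beyond the scatter). Compound 3 is estimated at 90 ug/mL, within 35 ug/mL to 220 ug/mL.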

Compound 3, solubility: >= 132 ug/mL
Compound 3: only a limit was reported; the forecaster's own chance of this, stated with the estimate: 30%; middle value at least 1.4-fold (0.16 log units) from the limit.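

In this assay, among the compounds shown here, 1-(hydroxymethyl)ethyl in place of oxan-4-yl on an amide-type nitrogen gives an at least 4.2-fold higher number from compound 1 to compound 3 (0.62 log units; beyond the scatter) as the first step that can be read at this position. For compound 3 the reading of >= 132 ug/mL is a limit of the assay and not a number. The six-membered ring of oxan-4-yl is therefore not required at this position for a reading beyond the scatter from compound 1.

From the compounds shown here alone, the full size of the step remains open. Also open, going by these compounds, is whether the hydroxyl or the loss of the ring accounts for it, which a plain isopropyl group could separate, and what an amine or a carboxylic acid on the chain would give.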